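The compounds below may be only part of what the source reports. "The series", "measured", "known", "first", "only" and "open" are said of these compounds alone.

Working notes on the series. In a physicochemical assay for solubility, in phosphate buffer, measured as kinetic solubility, at pH 7.4 (a higher number here means a more soluble compound, a lower number a less soluble compound), compound 2 `Cc1ccccc1-c1nc(CN2CCC(C(=O)NCCCN3CCCC(C(C)C)C3)CC2)c(C)o1` gives > 71 ug/mL, which is a limit and not a number. Compound 1 `Cc1ccccc1-c1nc(CN2CCC(C(=O)NCCCN3CCC(C)(C)CC3)CC2)c(C)o1` gives > 69 ug/mL, also a limit. Among the measured compounds shown here, the only measured step is a step that the two limits leave unreadable from compound 1 to compound 2. Compound 3 `Cc1ccccc1-c1nc(CN2CCC(C(=O)NCCCN3CCCC(CC(C)C)C3)CC2)c(C)o1` follows from compound 2 through (isobutyl in place of isopropyl on a saturated ring carbon), isobutyl in place of isopropyl on a saturated ring carbon. No step beyond the scatter is expected in this assay, in either direction, since a step that the two limits leave unreadable from compound 1 to compound 2 gives no readable size to carry forward. The step expected is an at least 1.0-fold lower number from compound 2 to compound 3 (0.03 log units; that floor lies within the scatter). For compound 3 the estimated value is 65 ug/mL, with an expected range of 30 ug/mL to 75 ug/mL.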

Compound 3, solubility: 54.9 ug/mL
Compound 3: the middle estimate sits 1.2-fold (0.07 log units) above what was measured; the range from low to high includes it.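

Among the compounds shown, only compound 3, with isobutyl in place of isopropyl on a saturated ring carbon, gives a number and not a limit in this assay: 54.9 ug/mL. This allows two steps to be read as floors: an at least 1.2-fold lower number from compound 2 to compound 3 (0.11 log units; that floor lies within the scatter) and an at least 1.2-fold lower number from compound 1 to compound 3 (0.09 log units; that floor lies within the scatter). The full size of the isobutyl step stays unknown because compound 2 gives only a limit: the limit of > 71 ug/mL in this assay, at which 1 of the 3 values shown sits.

The step from compound 1 to compound 2 cannot be read. Going by these compounds, whether a longer chain or an amine on this ring carbon would give a step beyond the scatter remains open.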